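The compounds below may be only part of what the source reports. "The series", "measured", "known", "first", "only" and "open" are said of these compounds alone.

Of the compounds shown here, two sharing one core have been measured in a functional assay on MIA PaCa-2 cells (Homo sapiens) for cytotoxicity, read by MTT assay, with a stated time of 72 h; a higher number here means a weaker inhibitor, a lower number a stronger inhibitor. Compound 1 `COc1ccc(-c2ccc(NC3=CC(=O)c4ncncc4C3=O)cc2)cc1` gives 2100 nM. Compound 2 `CC(=O)c1cccc(NC2=CC(=O)c3ncncc3C2=O)c1` gives 2300 nM. Compound 2 stands highest of the two numbers, yet its nearest neighbour, compound 1, lies so close that the two values sit within the scatter, and no order can be read between them. Compound 3 `O=C1C(Nc2cccc(B(O)O)c2)=CC(=O)c2ncncc21` has not yet been measured in this assay. It differs from compound 2 in one place: a group of 3 heavy atoms (1 boron, 2 oxygen; no ring) in place of a group of 3 heavy atoms (2 carbon, 1 oxygen; no ring), on an aromatic carbon, on an aromatic carbon of a six-membered aromatic ring of carbon only. Among the compounds with values here, no measured pair shows the effect of such an exchange, so the only guide is that compounds 1 and 2 sit close together despite their different substituents. The step of a 1.1-fold higher number from compound 2 to compound 3 (0.05 log units; within the scatter) is expected to stay within the scatter. The estimate for compound 3 is 2600 nM, between 900 nM and 7500 nM.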

Compound 3, half-maximal inhibitory concentration: > 10000 nM
Compound 3 gave a limit, no number; the forecaster's own chance of this, stated with the estimate: 10%; middle value at least 3.8-fold (0.58 log units) from the limit.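

In this assay compound 3 gave > 10000 nM which is a limit of the assay and not a number. Within the data shown here, replacing acetyl with a boronic acid on this aromatic carbon, meta to a large group, brings an at least 4.3-fold higher number from compound 2 to compound 3 (0.63 log units; beyond the scatter) and so shows that the read-out responds to the group held at this place, something the earlier compounds could not show, as no measured pair had isolated a change there. Going by these compounds, the true size of the step stays unknown, since the result rests on a limit: the limit of > 10000 nM in this assay, at which 1 of the 3 values shown sits.

This single pair cannot separate the effect of losing acetyl from that of introducing the boronic acid. On these data alone, how an amine or a carboxylic acid at the same place would read in this assay also remains open.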